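A few compounds are considered here, and "the series" means these few. Any claim that something is new, unique, unknown or untested is made for them only; others in the source may bear on it.

Measured compounds in a functional assay on the whole organism for inhibition, with Rattus norvegicus as the target; a lower number here means that less compound is needed, a higher number that more compound is needed for the effect:
- compound 1, `CC1CC/C(=N\Nc2cccc(Br)c2)c2ncc(C(=O)O)c(=O)n21`: > 320 umol/kg
- compound 2, `CC1CC/C(=N\Nc2cccc(C(F)(F)F)c2)c2ncc(C(=O)O)c(=O)n21`: > 1000 umol/kg

Both values are limits of the assay rather than numbers. Compound 2 therefore stands at a limit, the one described by the limit of > 1000 umol/kg in this assay, at which 1 of the 2 values shown sits. Compound 1 stands at the other limit, described by the limit of > 320 umol/kg in this assay, at which 1 of the 2 values shown sits. Going by the values given here, the only measured step, a step that the two limits leave unreadable from compound 1 to compound 2, cannot be read in size or direction, since each end is a limit.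

Compound 3, `CC(=O)c1cccc(N/N=C2\CCC(C)n3c2ncc(C(=O)O)c3=O)c1`, differs from compound 2 in one place: acetyl in place of trifluoromethyl on an aromatic carbon. Among the compounds with values here, no measured step bears on this change in a readable way, so nothing supports expecting a move beyond the scatter; the step from compound 2 to compound 3 is expected to be about a number no higher from compound 2 to compound 3 (the limit leaves the size open). Compound 3 is estimated at 1000 umol/kg, with a range from 300 umol/kg to 3000 umol/kg, and most likely this assay will again report only a limit.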

Compound 3, dose for 50% inhibition: > 1000 umol/kg
Compound 3 was reported as a limit; the forecaster's own chance of this, stated with the estimate: 80%; the middle value sits exactly at the limit.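

Compound 3 is again reported only as a limit in this assay, so its steps from compound 1 and from compound 2 cannot be read. The compounds shown leave open how much of each is needed for the effect, and whether bromo, trifluoromethyl or acetyl changes that amount.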